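Swapping trifluoromethyl for methyl on the shared core

The compounds below may be only part of what the source reports. "The series", "measured", "known", "first", "only" and "open" are said of these compounds alone.

Measured compounds:
Compound 1, `FC(F)(F)Oc1ccc(-c2cn(Cc3ccccc3)c3c2CNCC3)cc1`, 10000 nM
Compound 2, `Clc1ccc(-c2cn(Cc3ccccc3)c3c2CNCC3)cc1Cl`, 4470 nM
Compound 3, `FC(F)(F)c1ccc(-c2cn(Cc3ccccc3)c3c2CNCC3)cc1`, 167 nM

The read-out for all three is an assay on HEK293 cells for displacement of a labelled ligand from 5-hydroxytryptamine receptor 7 (Rattus norvegicus), with a stated time of 60 min; a higher number here means a weaker inhibitor, a lower number a stronger inhibitor. Among the three, compound 3 gives the lowest number: its nearest neighbour is compound 2, and the furthest is compound 1, both well beyond the scatter. Going by the values given here, the single one-place step recorded here runs a 60-fold lower number from compound 1 to compound 3 (1.78 log units; beyond the scatter), showing that the group on the aromatic ring of the shared core matters a great deal.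

Compound 4, `Cc1ccc(-c2cn(Cc3ccccc3)c3c2CNCC3)cc1`, is not yet measured. It differs from compound 3 in one place: methyl in place of trifluoromethyl on an aromatic carbon. Among the compounds with values here, no measured pair shows the same exchange, so the step cannot be read off directly. What the data do show is that changing this group moved the number by a large amount in the step from compound 1 to compound 3, and that compounds 1 and 2 sit far above compound 3. A change of similar weight is therefore plausible here, most likely toward a higher number, since compound 3 is already the best of the set. The expected step is a 5.4-fold higher number from compound 3 to compound 4 (0.73 log units; beyond the scatter). Compound 4 is estimated at 900 nM, with a range from 200 nM to 4500 nM.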

Compound 4, inhibition constant: 35 nM
The estimate for compound 4 lay 26-fold (1.41 log units) above the measured number; measured number outside the range, below it.
By their numbers in this assay, from the lowest: compound 4; then compound 3; then compound 2; then compound 1.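

In this assay, the exchange on an aromatic carbon para to a large group gives a 4.8-fold lower number from compound 3 to compound 4 (0.68 log units; beyond the scatter), so this place accepts a plain methyl and needs no fluorine for a low number. Compound 4 now has the lowest number of the four, and the wider gaps are a 290-fold lower number from compound 1 to compound 4 (2.46 log units; beyond the scatter) for methyl in place of trifluoromethoxy and a 130-fold lower number from compound 2 to compound 4 (2.11 log units; beyond the scatter) for 4-methylphenyl in place of 3,4-dichlorophenyl, so among these compounds the order at this place runs methyl, then trifluoromethyl, then trifluoromethoxy, with compound 2 differing from the others in more than this one group. Nothing here explains why methyl gives the lowest number, as no supporting measurement accompanies these results.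

The compounds shown leave open whether the trend continues with a bare hydrogen at this place or with a longer chain such as ethyl or propyl, and how a methoxy group or an amine would compare. They also cannot separate the contributions of the two chlorines in 3,4-dichlorophenyl, which a single chlorine on the ring would begin to address.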